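Widening the benzyl substituent on compound 2

The source may hold more compounds than are shown below. What is called first, only, known or untested is meant among the compounds shown, and "the series" means these compounds.

Compound 2 `COc1ccc(N2C(=O)N(Cc3ccccc3F)c3ccccc3S2(=O)=O)cc1OC` is the weakest binder of the three measured here: in an assay on HEK293 cells for displacement of a labelled ligand from Orexin receptor type 2 (Homo sapiens), read by scintillation counting, with a stated time of 90 min (on this read-out lower numbers stand for stronger inhibition and higher numbers for weaker inhibition), compound 2 gives 6.31 nM. Compound 1 `COc1cc(F)c(CN2C(=O)N(c3cc(OC)nc(OC)c3)S(=O)(=O)c3ccccc32)c(F)c1` gives 0.251 nM and compound 3 `COc1cc(F)c(CN2C(=O)N(c3ccc(OC)c(OC)n3)S(=O)(=O)c3ccccc32)c(F)c1` gives 0.2 nM, so both sit far below compound 2, beyond the scatter. Going by the values given here, the only single-point step among them is a 1.3-fold lower number from compound 1 to compound 3 (0.10 log units; within the scatter), which changes the aryl group on the ring nitrogen, not the benzyl group, and so does not bear on the change considered here.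

Compound 4 `COc1ccc(N2C(=O)N(Cc3c(F)cc(F)cc3OC)c3ccccc3S2(=O)=O)cc1OC` arises from compound 2 by 2,4-difluoro-6-methoxyphenyl in place of 2-fluorophenyl on a saturated chain carbon bound to an amide-type nitrogen in a ring. Among the compounds with values here, no measured pair isolates this change: compounds 1 and 3 carry a different fluoro-methoxybenzyl pattern and also a different aryl group, so their large gap to compound 2 mixes two changes. Still, the two strong compounds both carry a more substituted benzyl group, so a drop is expected. Compound 4 is expected to give about 1.5 nM in this assay, between 0.4 nM and 6 nM, a step of a 4.2-fold lower number from compound 2 to compound 4 (0.62 log units; beyond the scatter).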

Compound 4, inhibition constant: 6.31 nM
For compound 4 the middle estimate is 4.2-fold (0.62 log units) below the measured one; the measured number lies above the stated range.
By their numbers in this assay, from the lowest: compounds 3 and 1 (each within the scatter of the next); then compounds 2 and 4 (each within the scatter of the next).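

In this assay, replacing 2-fluorobenzyl with 2,4-difluoro-6-methoxybenzyl gives no change at the digits printed from compound 2 to compound 4 (within the scatter), even though a group of 10 heavy atoms with 1 hydrogen-bond acceptor replaces one of 7 heavy atoms with 0 acceptors. This is the first step shown that changes the group at this position while leaving the rest of the molecule untouched, and it shows that this particular enlargement leaves the number where it was. Nothing measured here explains why the number stays the same.

Going by these compounds, it remains open what the benzyl group of compound 1 would give on the core of compound 2, and whether the same change would also leave the number unmoved on the core of compound 1. On these data alone, how an amine or a carboxylic acid on this benzyl ring would read also remains open.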